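Swapping the terminal amine on an acrylamide side chain

The source may report more compounds than this note shows. Statements on the series, on what has been measured and on what is new or still open speak of the compounds shown alone.

Three compounds share a core in which an acrylamide-type group sits on a methoxy-bearing quinazoline-like scaffold, and all three were tested in a functional assay on A549 cells (Homo sapiens) for antiproliferative activity, read by MTT assay, with a stated time of 72 h; on this read-out higher numbers stand for weaker inhibition and lower numbers for stronger inhibition. Compound 1 `C=C(C)C(=O)Nc1cc2c(N3CCc4ccccc43)ncnc2cc1OC` gives 7320 nM. Compound 2 `CC/C=C/C(=O)Nc1cc2c(N3CCc4ccccc43)ncnc2cc1OC` gives 2470 nM, a change described as a 3.0-fold lower number from compound 1 to compound 2 (0.47 log units; beyond the scatter). Compound 3 `CCN(CC)C/C=C/C(=O)Nc1cc2c(N3CCc4ccccc43)ncnc2cc1OC` gives 1690 nM; against compound 1 this is a 4.3-fold lower number from compound 1 to compound 3 (0.64 log units; beyond the scatter), while the comparison a 1.5-fold lower number from compound 2 to compound 3 (0.16 log units; within the scatter) is within the scatter. Compound 3 thus has the lowest number of the three, although it cannot be separated from compound 2 on these data.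

Compound 4 `COc1cc2ncnc(N3CCc4ccccc43)c2cc1NC(=O)/C=C/CN1CCN(C)CC1` is not yet measured. It differs from compound 3 by 4-methylpiperazin-1-yl in place of diethylamino on a saturated chain carbon bound to a double-bonded chain carbon. Among the measured compounds shown here, the only measured step at the same place, a 1.5-fold lower number from compound 2 to compound 3 (0.16 log units; within the scatter), showed that exchanging the group on that saturated chain carbon left the number within the scatter. On that basis the exchange of one tertiary amine for another is expected to be a 1.1-fold lower number from compound 3 to compound 4 (0.05 log units; within the scatter), with no direction beyond the scatter predicted. Compound 4 is therefore estimated at 1500 nM in this assay, with a range from 600 nM to 4000 nM.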

Compound 4, half-maximal inhibitory concentration: 5360 nM
The estimate for compound 4 lay 3.6-fold (0.55 log units) below the measured number; measured number outside the range, above it.
By their numbers in this assay, from the lowest: compounds 3 and 2 (each within the scatter of the next); then compounds 4 and 1 (each within the scatter of the next).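

In this assay, the group on this saturated chain carbon bound to a double-bonded chain carbon proves not to be interchangeable among tertiary amines: the exchange of diethylamino for 4-methylpiperazin-1-yl gives a 3.2-fold higher number from compound 3 to compound 4 (0.50 log units; beyond the scatter) and so moves the number beyond the scatter, which the earlier step at this place had not done. Measured against the shorter alkyl end, 4-methylpiperazin-1-yl in place of methyl gives a 2.2-fold higher number from compound 2 to compound 4 (0.34 log units; beyond the scatter) in the direction opposite to the one diethylamino had taken, although that earlier step stayed within the scatter. The full 3-(4-methylpiperazin-1-yl)prop-1-en-1-yl group in place of 1-methylethenyl on a carbonyl carbon gives only a 1.4-fold lower number from compound 1 to compound 4 (0.14 log units; within the scatter) and so no longer stands apart from the 1-methylethenyl amide, as the diethylamino chain did. Nothing at hand accounts for the difference between the two amines.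

On these data alone, whether the ring itself or its further nitrogen goes with the higher number remains open, and a piperidine or a morpholine on this carbon would bear on that. How a smaller open-chain amine such as dimethylamino would read at this place is equally unsettled.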